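The source may hold more compounds than are shown below. What is called first, only, known or untested is meant among the compounds shown, and "the series" means these compounds.

Two compounds of the series have numbers in an assay on RPMI-8226 cells for antagonist activity at P2X purinoceptor 7 (Homo sapiens), read by calcium flux; a lower number here means a stronger inhibitor, a higher number a weaker inhibitor. Compound 1, `O=c1[nH]c2ccccc2n1CCCN1CCC(=C(c2ccccc2)c2ccccc2)CC1`, gives 2400 nM. Among the compounds with values here, compound 2, `Cc1cc2ncn(CCCCN3CCN(C(c4ccccc4)c4ccccc4)CC3)c2cc1C`, gives 770 nM, the lower of the two numbers, and the gap to compound 1 lies beyond the scatter; with only two compounds there is no step between single-point variants to lean on.

Compound 3, `N#Cc1cn(CCCCN2CCN(C(c3ccccc3)c3ccccc3)CC2)c2ccccc12`, differs from compound 2 by a group of 11 heavy atoms (9 carbon, 2 nitrogen; one five-membered aromatic ring with 1 hetero atom, one six-membered aromatic ring of carbon only) in place of a group of 11 heavy atoms (9 carbon, 2 nitrogen; one five-membered aromatic ring with 2 hetero atoms, one six-membered aromatic ring of carbon only), on a saturated chain carbon, four bonds along the chain from an amine nitrogen in a ring; the chain and the diphenylmethyl piperazine are kept. Within the data shown here, no measured pair shows a like exchange, so the size of the step is open. Since compound 2 stands at 770 nM and the bicyclic group is exchanged for another of the same size, the step from compound 2 to compound 3 in this assay is expected to be small, a 1.3-fold higher number from compound 2 to compound 3 (0.11 log units; within the scatter), with a slight lean towards a higher number. Compound 3 is therefore estimated at 1000 nM in this assay, within a range of 300 nM to 3500 nM.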

Compound 3, half-maximal inhibitory concentration: 1500 nM
Compound 3: middle estimate off by 1.5-fold (0.18 log units), on the low side; the range from low to high includes it.
By their numbers in this assay, from the lowest: compounds 2, 3 and 1 (each within the scatter of the next, the first and the last beyond it).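

In this assay, the exchange of 5,6-dimethyl-1H-benzimidazol-1-yl for a group of the same heavy-atom count, with one hetero atom in its five-membered aromatic ring and a triple bond outside the rings, gives a 1.9-fold higher number from compound 2 to compound 3 (0.29 log units; within the scatter). This first readable step shows that, for this one pair, the place on a saturated chain carbon, four bonds along the chain from an amine nitrogen in a ring, takes this exchange without a step beyond the scatter. No measurement shown bears on what lies behind this step.

Open, going by these compounds, is whether a smaller group at this place, such as a plain phenyl ring, a carboxylic acid or a longer chain, would give a step beyond the scatter. Also open, on these data alone, is what a fluorine on a phenyl ring of the diphenylmethyl piperazine would do.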